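Fluorine position on the benzyl group and cytotoxicity

A few compounds are considered here, and "the series" means these few. Any claim that something is new, unique, unknown or untested is made for them only; others in the source may bear on it.

Compound 1 `CCOC(=O)C1(Cc2ccccc2)CN(c2ccccc2)Cc2nnn(CCCCCO)c21` is tested in an ADME assay on HEL cells (Homo sapiens) for cytotoxicity, read by microscopy, with a stated time of 3 days; on this read-out lower numbers stand for higher toxicity in this test and higher numbers for lower toxicity in this test; compound 1 gives only the limit of > 100000 nM, not a number. Going by the values given here, compound 2 `Fc1ccc(Cn2nnc3c2CCN(c2ccc(C(F)(F)F)cc2)C3)cc1` gives 100000 nM in this assay, the only number in the set. The other value in the set sits at the limit of > 100000 nM in this assay, at which 1 of the 2 values shown sits. Compound 3 `Fc1cccc(Cn2nnc3c2CCN(c2ccc(C(F)(F)F)cc2)C3)c1` is unmeasured and differs from compound 2 by 3-fluorophenyl in place of 4-fluorophenyl on a saturated chain carbon bound to an aromatic nitrogen. No step is expected beyond the usual scatter, so no change at the digits printed from compound 2 to compound 3 (within the scatter) is the estimated change. Compound 3 is expected at 100000 nM, between 50000 nM and 100000 nM.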

Compound 3, minimum cytotoxic concentration: 100000 nM
The estimate for compound 3 equals the measured number at the digits printed, within the range that was stated.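

In this assay, going by these compounds alone, the exchange of 4-fluorobenzyl for 3-fluorobenzyl shows no change at the digits printed from compound 2 to compound 3 (within the scatter) and gives the first comparison at a single place. For this pair, moving the fluorine on the benzyl group does not register in this read-out. Compound 1 differs from both in more than one place, and its reading is a limit and not a number: the limit of > 100000 nM in this assay, at which 1 of the 3 values shown sits.

As far as these compounds go, whether an amine or a carboxylic acid on the benzyl ring would leave the reading unchanged stays open. So does the effect of a longer chain in place of the benzyl group.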